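Shortening the amide chain: isobutyl to propyl

The source may report more compounds than this note shows. Statements on the series, on what has been measured and on what is new or still open speak of the compounds shown alone.

The three measured compounds share one core and differ only in the group on the amide-type nitrogen. Compound 1 `C=CC1=C(C(=O)NC2CCCCC2)C(c2ccc(OC)cc2)OC1` carries a cyclohexyl group and in a functional assay on HeLa cells (Homo sapiens) for cytotoxicity, read by MTT assay, with a stated time of 24 h (on this read-out lower numbers stand for stronger inhibition and higher numbers for weaker inhibition), compound 1 gives 24800 nM. Compound 2 `C=CC1=C(C(=O)Nc2ccccc2OC)C(c2ccc(OC)cc2)OC1` carries a 2-methoxyphenyl group; in this assay compound 2 returns only the limit of the assay, > 100000 nM. Compound 3 `C=CC1=C(C(=O)NCC(C)C)C(c2ccc(OC)cc2)OC1` carries an isobutyl group; in this assay compound 3 likewise returns only a limit, > 100000 nM. Both replacements of cyclohexyl weaken the read-out: an at least 4.0-fold higher number from compound 1 to compound 2 (0.60 log units; beyond the scatter) and an at least 4.0-fold higher number from compound 1 to compound 3 (0.60 log units; beyond the scatter), while a step that the two limits leave unreadable from compound 2 to compound 3 because of the limit of > 100000 nM in this assay, at which 2 of the 3 values shown sit.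

Compound 4 `C=CC1=C(C(=O)NCCC)C(c2ccc(OC)cc2)OC1` is the next compound in line. The change from compound 3 is hydrogen in place of methyl on a saturated chain carbon bound to two saturated chain carbons. No measured step here alters a chain within the amide substituent; the steps shown only exchange whole groups, and compound 3 already sits at the limit. The step from compound 3 to compound 4 is therefore expected to be none beyond the scatter, written as a step that the limit leaves unreadable from compound 3 to compound 4. Compound 4 is estimated in this assay at 150000 nM, within a range from 40000 nM to 500000 nM, and most likely the assay will again report only a limit.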

Compound 4, half-maximal inhibitory concentration: 14000 nM
Estimate against measurement, compound 4: 11-fold (1.03 log units) above, and the stated range ends above it.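

In this assay, among these compounds, taking one methyl off the isobutyl group, on a saturated chain carbon bound to two saturated chain carbons, gives an at least 7.1-fold lower number from compound 3 to compound 4 (0.85 log units; beyond the scatter), so the amide substituent responds to a change inside a chain and not only to the exchange of whole groups, which is all the earlier steps showed. The propyl group also stands clear of the 2-methoxyphenyl group, with an at least 7.1-fold lower number from compound 2 to compound 4 (0.85 log units; beyond the scatter). Against the cyclohexyl group it shows no difference that can be told apart, with a 1.8-fold lower number from compound 1 to compound 4 (0.25 log units; within the scatter), so among the compounds shown a readable value on the amide-type nitrogen does not depend on a ring, while compound 2 and compound 3 show that neither a ring nor a branched chain as such secures one.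

The full size of the steps out of compound 2 and compound 3 stays unread, since each of these compounds gives only a limit: the limit of > 100000 nM in this assay, at which 2 of the 4 values shown sit. Whether an ethyl group, a butyl group or a longer chain, or a propyl chain ending in an amine, would hold the value of compound 4 remains open.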